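Shortening the Amide Chain on a Cytotoxicity Scaffold

A few compounds are considered here, and "the series" means these few. Any claim that something is new, unique, unknown or untested is made for them only; others in the source may bear on it.

Measured compounds:
compound 1, `C=CC1=C(C(=O)NCCCCC)C(c2ccc(Cl)c(Cl)c2)OC1`, gives > 100000 nM
compound 2, `C=CC1=C(C(=O)NC(C)(C)C)C(c2ccc(OC)cc2)OC1`, gives > 100000 nM
compound 3, `C=CC1=C(C(=O)NCc2ccccc2F)C(c2ccc(F)cc2)OC1`, gives > 100000 nM

The three measured compounds share one core and differ in the group on the amide nitrogen and in the substituents on the attached benzene ring. In a functional assay on A549 cells (Homo sapiens) for cytotoxicity, read by MTT assay, with a stated time of 24 h (a higher number here means a weaker inhibitor, a lower number a stronger inhibitor), compound 1 reaches only the limit of the test, and its value is therefore not a number. Compound 2 stands at the same limit. Compound 3 stands at that limit as well. Going by the values given here, compound 1 thus cannot be placed above or below the others: every value so far sits at the limit of > 100000 nM in this assay, at which 3 of the 3 values shown sit.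

Compound 4, `C=CC1=C(C(=O)NCC(C)C)C(c2ccc(Cl)c(Cl)c2)OC1`, differs from compound 1 by isopropyl in place of butyl on a saturated chain carbon bound to an amide-type nitrogen. Among the compounds with values here, no measured pair differs in only one place, so no step size can be read directly. Because all three measured compounds, with quite different amide substituents, sit at the limit of > 100000 nM in this assay, at which 3 of the 3 values shown sit, the expected step that the limit leaves unreadable from compound 1 to compound 4 is none beyond the scatter. Compound 4 is estimated at 150000 nM, within a range from 50000 nM to 500000 nM, most likely reported again as a limit.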

Compound 4, half-maximal inhibitory concentration: > 100000 nM
Compound 4: no number, only a limit (the forecaster's own chance of this, stated with the estimate: 85%); the middle value does not contradict the limit.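

Compound 1 and compound 4 both reach only a limit of the test, so no step between them can be read: the limit of > 100000 nM in this assay, at which 4 of the 4 values shown sit.

The compounds shown leave open how strongly any of them acts on these cells, and whether isopropyl in place of butyl changes that at all.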